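This account rests on a few compounds, and the source may have more. Where it says the series, first, only, none or still open, it means among the compounds named here.

Working notes on the series, read in a functional assay on A549 cells (Homo sapiens) for cytotoxicity, read by MTT assay, with a stated time of 72 h; on this read-out lower numbers stand for stronger inhibition and higher numbers for weaker inhibition. Compound 2 `O=C1c2c[n+]([O-])c3ccccc3c2C(=O)c2c1c1ccccc1n2CCN1CCCC1` gives 410 nM, within the scatter of compound 3 `O=C1c2c[n+]([O-])c3ccccc3c2C(=O)c2c1c1ccccc1n2Cc1cn([C@H]2C[C@H](O)[C@@H](CO)O2)nn1` at 350 nM, while compound 1 `O=C1c2c[n+]([O-])c3ccccc3c2C(=O)c2c1c1ccccc1n2Cc1cn([C@H]2O[C@H](CO)[C@@H](O)[C@H]2O)nn1` gives a higher 2680 nM, beyond the scatter. Still unmeasured is compound 4 `O=C1c2c[n+]([O-])c3ccccc3c2C(=O)c2c1c1ccccc1n2CCN1CCCCC1`: piperidin-1-yl in place of pyrrolidin-1-yl on a saturated chain carbon, two bonds along the chain from an aromatic nitrogen. This puts piperidin-1-yl in place of pyrrolidin-1-yl on a saturated chain carbon, two bonds along the chain from an aromatic nitrogen. For the measured compounds named here, the one measured step, a 7.7-fold lower number from compound 1 to compound 3 (0.88 log units; beyond the scatter), concerns oxolan-2-yl groups absent from both compounds here, so it is only a weak guide to this change. No shift beyond the scatter is therefore expected, in either direction. The expected step is a 1.0-fold lower number from compound 2 to compound 4 (0.01 log units; within the scatter). For compound 4 the estimated value is 400 nM, with an expected range of 170 nM to 950 nM.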

Compound 4, half-maximal inhibitory concentration: 1080 nM
For compound 4 the middle estimate is 2.7-fold (0.43 log units) below the measured one, and the stated range ends below it.
By their numbers in this assay, from the lowest: compounds 3 and 2 (each within the scatter of the next); then compound 4; then compound 1.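

At the saturated chain carbon, two bonds along the chain from an aromatic nitrogen, piperidin-1-yl in place of pyrrolidin-1-yl gives a 2.6-fold higher number from compound 2 to compound 4 (0.42 log units; beyond the scatter) in this assay, so the read-out separates these two rings at this position. For the compounds shown here, this is the first step read at this position, since the earlier step concerned only oxolan-2-yl groups. No measurement on hand accounts for the step.

As far as these compounds go, whether morpholin-4-yl or an open dimethylamino group here would read closer to compound 2 or compound 4 remains open. So does the outcome of a longer chain carrying either ring.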